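One Aryl Ether Swap Tested on Two Cores

The source may hold more compounds than are shown below. What is called first, only, known or untested is meant among the compounds shown, and "the series" means these compounds.

Compound 1 `Cc1cc(C)cc(Oc2cc(Nc3ccc(C#N)cc3)[nH]c(=O)c2I)c1` gives 24000 nM in an ADME assay on MT4 cells (Homo sapiens) for cytotoxicity, read by MTT assay, with a stated time of 5 days; on this read-out lower numbers stand for higher toxicity in this test and higher numbers for lower toxicity in this test.
Compound 2 `COc1cc(Oc2cc(C)cc(C)c2)cc(Nc2ccc(C#N)cc2)n1` gives 20000 nM in this assay.
Compound 3 `Cc1cc(C)c(Oc2cc(Nc3ccc(C#N)cc3)[nH]c(=O)c2I)c(C)c1` gives 34000 nM in this assay.

All three compounds carry the same aminobenzonitrile arm and an aryl ether on the central ring, and all three sit in the same low-toxicity region of this assay. Compound 3 differs from compound 1 only by 2,4,6-trimethylphenyl in place of 3,5-dimethylphenyl on an oxygen on an aromatic ring. That swap produced a 1.4-fold higher number from compound 1 to compound 3 (0.15 log units; within the scatter), so on this core the larger aryl group made no change that can be told apart from noise. Compound 2 stands on a different core; the difference between the two cores is not broken down here, and its value sits within the scatter of both compound 1 and compound 3.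

Compound 4 `COc1cc(Oc2c(C)cc(C)cc2C)cc(Nc2ccc(C#N)cc2)n1` has not yet been measured. Within the data shown here, it differs from compound 2 by 2,4,6-trimethylphenyl in place of 3,5-dimethylphenyl on an oxygen on an aromatic ring, the same change at the same place as the one already seen from compound 1 to compound 3. Among the measured compounds shown here, the expectation for compound 4 is therefore a small step, estimated as a 1.3-fold higher number from compound 2 to compound 4 (0.11 log units; within the scatter), because the only precedent for this change gave a 1.4-fold higher number from compound 1 to compound 3 (0.15 log units; within the scatter). That precedent is a single pair on another core, so the range is kept wide. Compound 4 is expected to give about 26000 nM, with a likely span from 11000 nM to 60000 nM.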

Compound 4, half-maximal cytotoxic concentration: 29000 nM
Beside the measured number, compound 4's estimate is 1.1-fold (0.05 log units) below it, and the stated range covers the measured number.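

In this assay, putting 2,4,6-trimethylphenyl in place of 3,5-dimethylphenyl on an oxygen on an aromatic ring, on the core of compound 2, gives a 1.5-fold higher number from compound 2 to compound 4 (0.16 log units; within the scatter). Set beside the same change on the core of compound 1, the two results agree, and the change carries over from one core to the other in the sense that it stays a small step on both: the same change on two cores in this assay, a 1.4-fold higher number (0.15 log units; within the scatter) from compound 1 to compound 3 and a 1.5-fold higher number (0.16 log units; within the scatter) from compound 2 to compound 4, 1.0-fold (0.01 log units) apart, within the scatter of two such steps. This does not show that the extra methyl group truly raises the number, since each step on its own cannot be told apart from the ordinary spread of repeated measurements, and two pairs in a single test cannot say how the change would behave on a third core or in any other test.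

Every aryl group on the ether oxygen shown here carries only methyl groups, and every compound keeps the same aminobenzonitrile arm. From the compounds shown here alone, how this test would respond to an amine or a carboxylic acid on that aryl group, or to a longer chain in place of the nitrile, remains open.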